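Substituent on the ring nitrogen: cyclobutyl to propyl

A few compounds are considered here, and "the series" means these few. Any claim that something is new, unique, unknown or untested is made for them only; others in the source may bear on it.

Working notes on a small set of three measured analogues sharing one core and differing only in the group on an aromatic nitrogen. Compound 1 `CC(C)c1onc(-c2c(Cl)cccc2Cl)c1COc1ccc(-c2nc3ccc(C(=O)O)cc3n2CC(C)(C)C)cc1` gives 861 nM in an assay on HEK-293T cells for antagonist activity at vitamin D3 receptor (Homo sapiens), read by a luciferase reporter, with a stated time of 24 h; on this read-out lower numbers stand for stronger inhibition and higher numbers for weaker inhibition. Compound 2 `CC(C)c1onc(-c2c(Cl)cccc2Cl)c1COc1ccc(-c2nc3ccc(C(=O)O)cc3n2C(C)C)cc1` gives 3550 nM in that assay, and compound 3 `CC(C)c1onc(-c2c(Cl)cccc2Cl)c1COc1ccc(-c2nc3ccc(C(=O)O)cc3n2C2CCC2)cc1` gives 1100 nM. Among these three numbers compound 3 stands second highest; its nearest neighbour is compound 1, with the step of a 1.3-fold higher number from compound 1 to compound 3 (0.11 log units; within the scatter), while the step of a 3.2-fold lower number from compound 2 to compound 3 (0.51 log units; beyond the scatter) separates it from compound 2.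

The next compound, compound 4 `CCCn1c(-c2ccc(OCc3c(-c4c(Cl)cccc4Cl)noc3C(C)C)cc2)nc2ccc(C(=O)O)cc21`, differs from compound 3 in one place: propyl in place of cyclobutyl on an aromatic nitrogen.

For the measured compounds named here, two measured steps bear on this change. Going from a branched four-carbon group to a three-carbon group, a 4.1-fold higher number from compound 1 to compound 2 (0.62 log units; beyond the scatter); going from that three-carbon group to the four-carbon ring, a 3.2-fold lower number from compound 2 to compound 3 (0.51 log units; beyond the scatter). Both point the same way: the three-carbon group sits at the weaker end of the set, and the two four-carbon groups within the scatter of each other. The propyl group of compound 4 matches compound 2 in carbon count but not in branching, so a shift toward compound 2 is expected, though perhaps not its full extent.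

Compound 4 is therefore expected to show a step of a 2.0-fold higher number from compound 3 to compound 4 (0.30 log units; within the scatter). The estimate for compound 4 in this assay is 2200 nM, with a range from 900 nM to 5500 nM.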

Compound 4, half-maximal inhibitory concentration: 1400 nM
Beside the measured number, compound 4's estimate is 1.6-fold (0.20 log units) above it; the measured number falls inside the stated range.
By their numbers in this assay, from the lowest: compounds 1, 3 and 4 (each within the scatter of the next); then compound 2.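

In this assay, the unbranched propyl group of compound 4 stands apart from the branched isopropyl group of compound 2 (a 2.5-fold lower number from compound 2 to compound 4 (0.40 log units; beyond the scatter)), so at this aromatic nitrogen the number follows the shape of the group and not only its carbon count. The propyl group has no ring, yet it stays within the scatter of the cyclobutyl group (a 1.3-fold higher number from compound 3 to compound 4 (0.10 log units; within the scatter)) and of the neopentyl group (a 1.6-fold higher number from compound 1 to compound 4 (0.21 log units; within the scatter)), so neither a ring nor a bulky branched end is needed to reach the level shared by compound 1, compound 3 and compound 4. Among the four compounds, compound 2 alone is set apart, which makes isopropyl the exception at this position rather than the end of a trend with group size.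

No measurement shown gives a reason for the gap between the propyl and isopropyl groups.

From the compounds shown here alone, it remains open whether smaller or longer unbranched chains, such as ethyl or butyl, hold the level of compound 4. Also open, going by these compounds, is whether other branched or ring groups, such as sec-butyl or cyclopropyl, fall with compound 2 or with compound 3.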